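This account rests on a few compounds, and the source may have more. Where it says the series, first, only, none or still open, it means among the compounds named here.

Series notes on the shared core. Compound 1 `Cc1ccc2[nH]c(C(=O)N[C@H]3CN(S(=O)(=O)c4cccnc4)C[C@@H]3C(=O)NCCN(C)C)cc2c1` and compound 2 `Cc1csc(C(=O)N[C@H]2CN(S(=O)(=O)c3ccccc3)C[C@@H]2C(=O)N[C@H]2CCCNC2)n1` have been run in an ADME assay on cells (Hepatocyte, Rattus norvegicus) for metabolic stability; on this read-out lower numbers stand for slow clearance and higher numbers for fast clearance. Compound 1 gives 8 uL/min in this assay. For compound 2 this assay returns only < 1 uL/min, which is a limit of the assay rather than a number. Compound 2 therefore stands at the slow-clearance end of the two readings shown, sitting at the limit of < 1 uL/min in this assay, at which 1 of the 2 values shown sits, and nothing more exact about its value is known. Compound 3 `O=C(N[C@H]1CN(S(=O)(=O)c2ccccc2)C[C@@H]1C(=O)N[C@H]1CCCNC1)c1cc(-c2ccccc2Cl)on1` has not yet been measured in this assay. It differs from compound 2 in one place: a group of 12 heavy atoms (9 carbon, 1 nitrogen, 1 oxygen, 1 chlorine; one five-membered aromatic ring with 2 hetero atoms, one six-membered aromatic ring of carbon only) in place of a group of 6 heavy atoms (4 carbon, 1 nitrogen, 1 sulfur; one five-membered aromatic ring with 2 hetero atoms), on a carbonyl carbon. Going by the values given here, no step between measured compounds is available, so the size of this change can only be anticipated. Since compound 2 starts from a limit, whatever step is expected for compound 3 can only run toward faster clearance or stay within the usual scatter. The expected step in this assay is an at least 3.0-fold higher number from compound 2 to compound 3 (0.47 log units; beyond the scatter), a modest move toward faster clearance. Compound 3 is accordingly estimated to give about 3 uL/min in this assay, with a plausible range from 1 uL/min to 12 uL/min, while a reading again at the limit remains possible.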

Compound 3, intrinsic clearance in a liver preparation (reported as CLH), per the amount of preparation that the assay uses: 8.3 uL/min
Estimate against measurement, compound 3: 2.8-fold (0.44 log units) below, and the stated range covers the measured number.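

In this assay, the group on the carbonyl carbon whose other neighbour is the amide-type nitrogen proves able to shift the read-out: replacing 4-methyl-1,3-thiazol-2-yl with the larger group of compound 3, which holds a five-membered aromatic ring with 2 hetero atoms, a six-membered aromatic ring of carbon only and a chlorine, gives an at least 8.3-fold higher number from compound 2 to compound 3 (0.91 log units; beyond the scatter). Both groups have the same counts of hydrogen-bond donors and acceptors and no net charge, so the step goes with a change in size and ring content and not with a change in those counts. Compound 2 reads as a limit of the assay and not as a number, so the step can be taken only as a minimum: the limit of < 1 uL/min in this assay, at which 1 of the 3 values shown sits.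

The two groups differ in several features at once, and the compounds shown do not separate the share of the chlorine, the added six-membered aromatic ring or the exchanged five-membered ring. Also open, as far as these compounds go, is how a plain phenyl group, or a group bearing an amine or a carboxylic acid, would read on this carbonyl carbon in this assay.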